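A new group on the carbonyl of compound 3

A few compounds are considered here, and "the series" means these few. Any claim that something is new, unique, unknown or untested is made for them only; others in the source may bear on it.

compound 1 `CCC[C@]1(C(=O)N2CC[C@](c3ccc(C(F)(C(F)(F)F)C(F)(F)F)cc3)(S(=O)(=O)c3ccc(F)cc3)C2)CC[C@H](C(=O)O)CC1`: "not determined" (no result reported)
compound 2 `COC[C@]1(C(=O)N2CC[C@](c3ccc(C(F)(C(F)(F)F)C(F)(F)F)cc3)(S(=O)(=O)c3ccc(F)cc3)C2)CC[C@H](C(=O)O)CC1`: 88%
compound 3 `O=C([C@H]1CC[C@H](CO)CC1)N1CC[C@](c2ccc(C(F)(C(F)(F)F)C(F)(F)F)cc2)(S(=O)(=O)c2ccc(F)cc2)C1`: 63%

These entries come from an ADME assay on microsomes from liver (Mus musculus) for metabolic stability, with a stated time of 10 min (on this read-out lower numbers stand for a less stable compound and higher numbers for a more stable compound), and compound 1 has no number there. Compound 3 gives 63% as the lower of the two numbers, and compound 2 gives 88% as the higher one. Still unmeasured is compound 4 `O=C(C1CCS(=O)(=O)CC1)N1CC[C@](c2ccc(C(F)(C(F)(F)F)C(F)(F)F)cc2)(S(=O)(=O)c2ccc(F)cc2)C1` and it is the subject here. It carries 1,1-dioxothian-4-yl in place of 4-(hydroxymethyl)cyclohexyl on a carbonyl carbon and otherwise matches compound 3.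

For the measured compounds named here, only one measured step touches this place. That step, a number 25 percentage points lower from compound 2 to compound 3 (beyond the scatter), is modest but beyond the scatter, so a change on this carbonyl carbon can move the number. The step arrives at the very group that now leaves, which gives a weak hint of direction and no more. Going by the values given here, no measured compound carries 1,1-dioxothian-4-yl, so the size stays uncertain. A modest rise is therefore expected, with the estimated step being a number 12 percentage points higher from compound 3 to compound 4 (beyond the scatter) and a result within the scatter still possible. For compound 4 the expected value is 75% with an estimated range from 55% to 92% in this assay once it is measured.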

Compound 4, percent of the compound remaining: 96%
Compound 4: middle estimate off by 21 percentage points, on the low side; measured number above the stated range.
By their numbers in this assay, from the lowest: compound 3; then compounds 2 and 4 (each within the scatter of the next).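

In this assay, putting 1,1-dioxothian-4-yl in place of 4-(hydroxymethyl)cyclohexyl on the carbonyl carbon gives a number 33 percentage points higher from compound 3 to compound 4 (beyond the scatter), so this position can produce a large step and not only the modest one seen before. The other new step, a number 8 percentage points higher from compound 2 to compound 4 (within the scatter), shows that 1,1-dioxothian-4-yl and 4-carboxy-1-(methoxymethyl)cyclohexyl cannot be told apart on this read-out, so among these compounds a carboxylic acid on the ring is not needed to reach a number at this level. No measurement shown here explains why the number moves with these groups.

For the compounds shown here, with only three numbers at this position, it remains open whether the result depends on the ring with its two oxygens on sulfur or would also appear with another group on the carbonyl carbon, such as an unsubstituted cyclohexyl, a tetrahydropyran-4-yl ring or a piperidin-4-yl amine. The compounds shown also leave open whether a hydroxymethyl group on a ring always goes with a lower number, since compound 3 is the only example that carries one.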